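Chloro added to the sulfonyl aryl ring of compound 3

The source may hold more compounds than are shown below. What is called first, only, known or untested is meant among the compounds shown, and "the series" means these compounds.

Compound 3 `O=S(=O)(c1ccccc1)c1cn(C2CCCNC2)c2ncccc12` stands at the highest number of the three measured in an assay on HeLa cells for displacement of a labelled ligand from 5-hydroxytryptamine receptor 6 (Homo sapiens) (on this read-out higher numbers stand for weaker inhibition and lower numbers for stronger inhibition), where compound 3 gives 4.9 nM. Compound 1 `CN1CCC(n2cc(S(=O)(=O)c3cccc(Cl)c3)c3cccnc32)C1` gives 1.5 nM in this assay, and compound 2 `CCN1CCC(n2cc(S(=O)(=O)c3cccc(Cl)c3)c3cccnc32)C1` gives 3.3 nM; against compound 2 the gap to compound 3 lies within the scatter, against compound 1 it lies beyond it. For the measured compounds named here, the only single-point step measured so far is a 2.2-fold higher number from compound 1 to compound 2 (0.34 log units; beyond the scatter), which concerns the amine substituent and not the aryl ring.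

Compound 4 `O=S(=O)(c1cccc(Cl)c1)c1cn(C2CCCNC2)c2ncccc12` differs from compound 3 by chloro in place of hydrogen on an aromatic carbon. Going by the values given here, no measured pair isolates this change: compounds 1 and 2 carry the chloro, but they also differ from compound 3 in the amine-bearing ring, so their values cannot be read as a chloro effect. What the numbers show is that the two chloro-bearing compounds sit at or below the number of compound 3, with the spread between them modest.

On that basis compound 4 is expected to give a number near that of compound 3, with at most a small move toward a lower number, a step of a 1.6-fold lower number from compound 3 to compound 4 (0.21 log units; within the scatter) that is estimated to remain within the scatter. The estimate for compound 4 in this assay is 3 nM, with a range from 1 nM to 10 nM.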

Compound 4, inhibition constant: 1.3 nM
Beside the measured number, compound 4's estimate is 2.3-fold (0.36 log units) above it, within the range that was stated.
By their numbers in this assay, from the lowest: compounds 4 and 1 (each within the scatter of the next); then compounds 2 and 3 (each within the scatter of the next).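

In this assay, the change from phenyl to 3-chlorophenyl can now be read on its own, and chloro in place of hydrogen on this aromatic carbon gives a step beyond the scatter (a 3.8-fold lower number from compound 3 to compound 4 (0.58 log units; beyond the scatter)). This shows that the chloro contributes to the low numbers on a piperidin-3-yl compound, which the earlier chloro-bearing compounds could not show, since each of them also carries a different amine-bearing ring. With the 3-chlorophenyl group held constant, the swap of amine-bearing group reads two ways: piperidin-3-yl in place of 1-ethylpyrrolidin-3-yl gives a step beyond the scatter (a 2.5-fold lower number from compound 2 to compound 4 (0.40 log units; beyond the scatter)), while piperidin-3-yl in place of 1-methylpyrrolidin-3-yl stays within it (a 1.2-fold lower number from compound 1 to compound 4 (0.06 log units; within the scatter)). The data shown offer no measurement that accounts for the chloro step.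

As far as these compounds go, whether a fluoro, a methoxy or a longer chain on the same aromatic carbon would match the chloro remains open. Also open, from the compounds shown here alone, is whether phenyl to 3-chlorophenyl gives a similar step on compounds carrying 1-methylpyrrolidin-3-yl or 1-ethylpyrrolidin-3-yl.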